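A Larger Group on the Ring Nitrogen of Compound 1

The source may hold more compounds than are shown below. What is called first, only, known or untested is meant among the compounds shown, and "the series" means these compounds.

Compound 1 `COc1ccc(-c2cc(=O)c3c(OC)cc(OC)cc3n2C)cc1` is only weakly active. Among the measured compounds shown here, in a functional assay on KOPN-8 cells (Homo sapiens) for antiproliferative activity, with a stated time of 72 h (a higher number here means that more compound is needed for the effect, a lower number that less compound is needed), compound 1 gives 30000 nM, the single definite number among the two measured compounds. Compound 2 `COC(=O)c1cc(=O)c2c(OC)cc(OC)cc2n1C` carries methoxycarbonyl in place of 4-methoxyphenyl on an aromatic carbon. In this assay compound 2 gives > 19000 nM, which is a limit of the assay and not a number. The step that the limit leaves unreadable from compound 1 to compound 2 therefore cannot be read, as the limit of > 19000 nM in this assay, at which 1 of the 2 values shown sits, shows. Compound 3 `COc1ccc(-c2cc(=O)c3c(OC)cc(OC)cc3n2S(=O)(=O)c2ccc(C=O)cc2)cc1` keeps the core of compound 1 and alters a different place: (4-formylphenyl)sulfonyl in place of methyl on an aromatic nitrogen. For the measured compounds named here, no measured step touches the aromatic nitrogen, and the one measured step at another place is unreadable, so there is no basis for expecting a shift beyond the scatter in either direction. The expected step of no change at the digits printed from compound 1 to compound 3 (within the scatter) is accordingly set at no change. In this assay compound 3 is expected to give roughly 30000 nM, within a wide range from 8000 nM to 100000 nM, and a reported limit instead of a number is quite possible.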

Compound 3, half-maximal effective concentration: > 34400 nM
Compound 3: a limit, no number; the forecaster's own chance of this, stated with the estimate: 50%; middle value at least 1.1-fold (0.05 log units) from the limit.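

Among the compounds shown here, on the aromatic nitrogen, (4-formylphenyl)sulfonyl in place of methyl gives an at least 1.1-fold higher number from compound 1 to compound 3 (0.05 log units; that floor lies within the scatter) in this assay, the first measured step at this position. In this assay compound 3 gives > 34400 nM, which is a limit of the assay and not a number. This much larger group therefore brings no lower number than methyl, but the true size of the step stays hidden, and it may or may not lie beyond the scatter, because the reading stops at a limit: the limit of > 34400 nM in this assay, at which 1 of the 3 values shown sits.

Going by these compounds, only methyl and (4-formylphenyl)sulfonyl appear on this nitrogen, so it remains open whether a different kind of group there, such as a benzyl group or a short chain ending in an amine, would lower the number. On these data alone, it also remains open which part of the new group matters, since a plain phenylsulfonyl group, without the formyl, would be needed to separate the effect of the sulfonyl link and ring from that of the formyl.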